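Replacing methoxy with (trifluoromethyl)sulfanyl: what to expect

A few compounds are considered here, and "the series" means these few. Any claim that something is new, unique, unknown or untested is made for them only; others in the source may bear on it.

Compound 1 `COc1cccc(NC(=O)C(Cl)Cl)c1`: 25800 nM
Compound 2 `O=C(Nc1cccc(SC(F)(F)F)c1)C(Cl)Cl`: 14100 nM
Compound 3 `COc1ccc(NC(=O)C(Cl)Cl)cc1`: 80900 nM

These three compounds were tested in a functional assay on A549 cells (Homo sapiens) for antiproliferative activity, read by MTT assay, with a stated time of 72 h; on this read-out higher numbers stand for weaker inhibition and lower numbers for stronger inhibition. Compound 1 and compound 3 are built from the same atoms, joined differently; the difference between the two cores is not broken down here. Compound 3 gives the highest number of the three, and its gap to compound 1 lies beyond the scatter, as does its gap to compound 2.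

Compound 4 `O=C(Nc1ccc(SC(F)(F)F)cc1)C(Cl)Cl` has not been measured. It differs from compound 3 in one change: (trifluoromethyl)sulfanyl in place of methoxy on an aromatic carbon. The same kind of change links compound 1 to compound 2: (trifluoromethyl)sulfanyl in place of methoxy on an aromatic carbon. The two changes are not the same, though, since in one the place is meta to a group of 6 heavy atoms and in the other it is para to a group of 6 heavy atoms. Measured, that earlier change made a 1.8-fold lower number from compound 1 to compound 2 (0.26 log units; within the scatter).

In this assay a step of about a 1.8-fold lower number from compound 3 to compound 4 (0.25 log units; within the scatter) is expected for compound 4, resting on the earlier step of a 1.8-fold lower number from compound 1 to compound 2 (0.26 log units; within the scatter) from compound 1 to compound 2. Compound 4 is therefore estimated at 45000 nM, most likely between 20000 nM and 110000 nM.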

Compound 4, half-maximal inhibitory concentration: 10600 nM
For compound 4 the middle estimate is 4.2-fold (0.63 log units) above the measured one; measured number below the stated range.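

In this assay, (trifluoromethyl)sulfanyl in place of methoxy gives a 7.6-fold lower number from compound 3 to compound 4 (0.88 log units; beyond the scatter), so on the core of compound 3 this change clearly moves the number. The size of the step does not carry over from one core to the other, and a step measured on one core was a poor guide to the step on the other: the same change on two cores in this assay, a 1.8-fold lower number (0.26 log units; within the scatter) from compound 1 to compound 2 and a 7.6-fold lower number (0.88 log units; beyond the scatter) from compound 3 to compound 4, 4.2-fold (0.62 log units) apart, beyond the scatter of two such steps. Going by these compounds alone, this rests on only two pairs of compounds, and it does not show why the two steps differ or how large the step would be on any further core.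

The compounds shown leave open how other groups would behave in the same place, such as a plain trifluoromethyl, an amine or a carboxylic acid. They also leave open whether the two steps would stay this far apart in a different cell line.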